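Chloro on the anilide ring in two thioester series

This account rests on a few compounds, and the source may have more. Where it says the series, first, only, none or still open, it means among the compounds named here.

Measured so far:
compound 1, `CC(=O)SCCC(CCCCC(=O)Nc1ccccc1)SC(C)=O`: 14.1%
compound 2, `CC(=O)SCCC(CCCCC(=O)Nc1cccc(Cl)c1)SC(C)=O`: 20.8%
compound 3, `O=C(CCCCC(CCSC(=O)c1ccccc1)SC(=O)c1ccccc1)Nc1ccccc1`: "not active" (no number reported)

All compounds here were tested in a functional assay on Bel-7402 cells (Homo sapiens) for inhibition, read by MTT assay, with a stated time of 24 h, tested at 100 ug/mL; on this read-out higher numbers stand for more inhibition of growth at the one concentration tested and lower numbers for less inhibition of growth. Compound 1 carries two thioacetyl groups on its chain and an unsubstituted anilide; in this assay compound 1 gives 14.1%. Compound 2 differs by chloro in place of hydrogen on an aromatic carbon and gives 20.8%, so the step of a number 6.7 percentage points higher from compound 1 to compound 2 (within the scatter).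

Compound 3 replaces the two thioacetyl groups of compound 1 with thiobenzoyl groups; the difference between the two cores is not broken down here. For compound 3 the assay gives no single number, only the report "not active" (no number reported).

Compound 4, `O=C(CCCCC(CCSC(=O)c1ccccc1)SC(=O)c1ccccc1)Nc1ccccc1Cl`, has not been measured. It differs from compound 3 by chloro in place of hydrogen on an aromatic carbon. This is the same kind of change as from compound 1 to compound 2, but not the same: there the chloro entered meta to a large group, here it enters ortho to a large group. Because a number 6.7 percentage points higher from compound 1 to compound 2 (within the scatter) was within the scatter, and because compound 3 gave "not active" (no number reported), a small step is expected here too. Compound 4 is therefore estimated at 10%, with the expected range 0% to 25%, and a real chance that it is again reported only as not active.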

Compound 4, percent growth inhibition at one concentration: "not active" (no number reported)
Compound 4: no number reported; no gap can be computed for the estimate.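

Compound 3 gives "not active" (no number reported) in this assay and compound 4 gives "not active" (no number reported) as well, so no step can be read between these two compounds. They leave open whether chloro in place of hydrogen on the anilide ring changes growth inhibition at all on the core of compound 3. No measurement shown here offers an explanation for this result.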